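The source may report more compounds than this note shows. Statements on the series, on what has been measured and on what is new or still open speak of the compounds shown alone.

Compound 3 `CC1=C(C(N)=O)C(c2ccoc2)NC(=O)N1` gives 2% in an assay on membranes from HeLa cells for displacement of a labelled ligand from adenosine receptor A3 (Homo sapiens), read by scintillation counting, with a stated time of 180 min, tested at 1 uM (on this read-out lower numbers stand for less inhibition and higher numbers for more inhibition at the one concentration tested (going by the name of the read-out)), level with compound 1 `CCCC(=O)C1=C(C)NC(=O)NC1c1ccoc1`, which gives 2%, and together the two stand as the lowest of three numbers, while compound 2 `CC1=C(C(=O)CC(C)C)C(c2ccoc2)NC(=O)N1` gives 18%. Compound 4 `CC1=C(C(=O)SC(C)C)C(c2ccoc2)NC(=O)N1` differs from compound 3 in one place: isopropylsulfanyl in place of amino on a carbonyl carbon. Within the data shown here, two measured steps bear on this change. The first, no change at the digits printed from compound 1 to compound 3 (within the scatter), shows that exchanging amino for propyl on the same carbonyl carbon left the read-out unchanged. The second, a number 16 percentage points lower from compound 2 to compound 3 (beyond the scatter), shows that amino in place of isobutyl lowered it modestly, so the reverse exchange to a three-carbon substituent may recover part of that. For compound 4 a modest rise, a number 10 percentage points higher from compound 3 to compound 4 (within the scatter), is expected in this assay. Compound 4 is therefore estimated at 12%, with a range from 0% to 30%.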

Compound 4, a percentage reported as inhibition, at one concentration (the size of the read-out at that concentration, not a potency): 3%
Beside the measured number, compound 4's estimate is 9 percentage points above it; low and high end bracket the measured number.
By their numbers in this assay, from the lowest: compounds 1, 3 and 4 (each within the scatter of the next); then compound 2.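

In this assay, isopropylsulfanyl on the carbonyl carbon does not match isobutyl, as shown by a number 15 percentage points lower from compound 2 to compound 4 (beyond the scatter), while it stays level with amino and propyl, as shown by a number 1 percentage points higher from compound 3 to compound 4 (within the scatter) and a number 1 percentage points higher from compound 1 to compound 4 (within the scatter). Among the four groups on this carbonyl carbon, only isobutyl therefore stands apart. Nothing measured here accounts for this difference. Going by these compounds, whether an isopropoxy group, a tert-butyl group or a longer branched chain on this carbonyl carbon would group with isobutyl or with the other three remains open.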